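This account rests on a few compounds, and the source may have more. Where it says the series, first, only, none or still open, it means among the compounds named here.

Compound 1 `Cc1nc2cc(-c3ccccc3)nn2c(N2CCC(C)(C)CC2)c1C(OC(C)(C)C)C(=O)O`: 703 nm/s
Compound 2 `Cc1nc2cc(-c3cccc(-c4ccccc4)c3)nn2c(-c2cc(F)c3c(c2C)CCCO3)c1[C@H](OC(C)(C)C)C(=O)O`: 733 nm/s
Compound 3 `Cc1nc2cc(-c3cccc(-c4ccccc4F)c3)nn2c(-c2cc(F)c3c(c2C)CCCO3)c1[C@H](OC(C)(C)C)C(=O)O`: 608 nm/s

These three readings come from an ADME assay for permeability, using PAMPA, with a stated time of 4 h, at pH 7.4, tested at 100 uM; a lower number here means that the compound crosses the layer more slowly, a higher number that the compound crosses the layer faster. Compound 3 lies within the scatter of both compound 1 and compound 2, so the three cannot be ranked. The next compound is compound 4 `COc1ccc(-c2cccc(-c3cc4nc(C)c([C@H](OC(C)(C)C)C(=O)O)c(-c5cc(F)c6c(c5C)CCCO6)n4n3)c2)cn1`, which carries 6-methoxypyridin-3-yl in place of 2-fluorophenyl on an aromatic carbon.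

Among the compounds with values here, only one measured step touches this part of the structure. It is a 1.2-fold lower number from compound 2 to compound 3 (0.08 log units; within the scatter), a fluoro in place of hydrogen on an aromatic carbon, and it stays within the scatter. Within the data shown here, no measured step exchanges the whole ring or brings in a methoxy group, so this evidence is indirect and the range must stay wide. No shift beyond the scatter is therefore expected in this assay. The expected change is a 1.1-fold lower number from compound 3 to compound 4 (0.04 log units; within the scatter), with a slight lean downward that is only a guess.

The estimated value for compound 4 is 550 nm/s, with an expected range from 300 nm/s to 950 nm/s.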

Compound 4, apparent permeability: 514 nm/s
The estimate for compound 4 lay 1.1-fold (0.03 log units) above the measured number; the range from low to high includes it.
By their numbers in this assay, from the lowest: compounds 4, 3, 1 and 2 (each within the scatter of the next).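

In this assay, the step at this position, on an aromatic carbon of a six-membered aromatic ring of carbon only, now covers the exchange of a whole ring: it is a 1.2-fold lower number from compound 3 to compound 4 (0.07 log units; within the scatter), and against the plain phenyl it is a 1.4-fold lower number from compound 2 to compound 4 (0.15 log units; within the scatter). Earlier, only a fluoro had been read here, whereas 6-methoxypyridin-3-yl brings a ring hetero atom and hydrogen-bond acceptors that 2-fluorophenyl lacks, and both steps still stay within the scatter. No measurement shown offers an explanation for these readings.

The compounds shown leave open whether an outer ring carrying an amine, such as piperazin-1-yl, or a carboxylic acid would also stay within the scatter. They also cannot separate the ring nitrogen from the methoxy group, which a 4-methoxyphenyl would address.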